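This account rests on a few compounds, and the source may have more. Where it says the series, first, only, none or still open, it means among the compounds named here.

Working notes on the series. Two members have been run in a functional assay on the whole organism (strain CD-1) with Mus musculus as the target, with a stated time of 20 min (a lower number here means that less compound is needed, a higher number that more compound is needed for the effect), and carry numbers. Compound 1 `CC(=O)OC[C@@H]1CN(C(C)=O)CCN1S(=O)(=O)c1ccc(F)cc1` gives 1 mg/kg in this assay. Compound 2 `CC(=O)N1CCN(S(=O)(=O)c2ccc(F)cc2)C(CO)C1` gives 1 mg/kg in this assay, which is level with compound 1 at the digits shown and lies within the usual scatter, so no order between the two can be read from it. Compound 3 `COCC1CN(S(=O)(=O)c2ccc(F)cc2)CCN1C(C)=O` is the third member measured. In this assay compound 3 gives only a limit, > 10 mg/kg, and no number; this is the limit of > 10 mg/kg in this assay, at which 1 of the 3 values shown sits. For the measured compounds named here, no two of the three differ in a single place, so no measured step is available within the set.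

Compound 4 `CC(=O)OCC1CN(C(C)=O)CCN1S(=O)(=O)c1ccc(F)cc1` is still to be measured in this assay. It differs from compound 2 by acetyl in place of hydrogen on an oxygen on a saturated carbon. Going by the values given here, the acetoxymethyl group that results is the one already carried by compound 1, which gives 1 mg/kg in this assay, while compound 2 with the hydroxymethyl gives 1 mg/kg. On that basis the step from compound 2 to compound 4 is expected to be no change at the digits printed from compound 2 to compound 4 (within the scatter), that is, none beyond the scatter. Compound 4 is therefore estimated at about 1 mg/kg in this assay, with a range from 0.5 mg/kg to 3 mg/kg.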

Compound 4, minimum effective dose in the Mus musculus assay: 0.1 mg/kg
Beside the measured number, compound 4's estimate is 10-fold (1.00 log units) above it; measured number outside the range, below it.
By their numbers in the Mus musculus assay, from the lowest: compound 4; then compounds 1 and 2 (each within the scatter of the next). At a limit, above all of these: compound 3.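

For the compounds shown here, in the Mus musculus assay, acetyl in place of hydrogen on an oxygen on a saturated carbon gives a 10-fold lower number from compound 2 to compound 4 (1.00 log units; beyond the scatter), the first measured step and one that lies beyond the scatter. Going by these compounds alone, the hydroxy to acetoxy change is therefore not silent at this place, which the earlier compounds, with no step among them, could not show. The acetoxymethyl group alone does not settle the number, since a 10-fold lower number from compound 1 to compound 4 (1.00 log units; beyond the scatter) joins two compounds with the same atoms and bonds, and what separates them is this: the fact that one of compounds 1 and 4 is drawn with a defined configuration and the other without, at the place where they differ

In a physicochemical assay for metabolic stability, read by LC-MS, in phosphate buffer, tested at 1 uM (a higher number here means that the compound lasts longer, a lower number that the compound disappears faster), compound 2 gives >= 4 h, which is a limit of the assay. In the physicochemical assay compound 4 gives >= 4 h, also a limit, so the step between the two cannot be read in that assay. On these data alone, it stays open how a longer acyl chain or an amine-bearing ester on the same oxygen would read in the Mus musculus assay, and how the number of compound 4 relates to the configuration at its stereocentre.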